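A few compounds are considered here, and "the series" means these few. Any claim that something is new, unique, unknown or untested is made for them only; others in the source may bear on it.

Working notes on the series. In a functional assay on DU-145 cells (Homo sapiens) for inhibition, read by CCK-8 assay, with a stated time of 72 h (on this read-out higher numbers stand for weaker inhibition and lower numbers for stronger inhibition), compound 1 (`O=C(/C=C/c1cccnc1)NCCCc1cccc(S(=O)(=O)Nc2ccccc2)c1`) gives 165 nM and compound 2 (`Cc1cccc(NS(=O)(=O)c2cccc(CCCCCCNC(=O)/C=C/c3cccnc3)c2)c1`) gives 41.7 nM as the lower of the two numbers, with the gap between them beyond the usual scatter. For the measured compounds named here, no pair of measured compounds differs in one place only, so the series offers no measured step to draw on.

Compound 3 (`O=C(/C=C/c1cccnc1)NCCCCCCc1cccc(S(=O)(=O)Nc2ccc(Cl)cc2)c1`) is not yet measured. It departs from compound 2 at a single place, with 4-chlorophenyl in place of 3-methylphenyl on a sulfonamide nitrogen and the rest of the structure kept. The data give neither size nor direction for a change at this place. Compound 2 at 41.7 nM is therefore the anchor, and no step beyond the scatter is expected in this assay in either direction. Going by the values given here, the estimated 1.0-fold lower number from compound 2 to compound 3 (0.02 log units; within the scatter) stays small, and a wide range is kept because only two values are available. For compound 3 the estimated value is 40 nM with an expected range from 14 nM to 110 nM in repeated measurements.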

Compound 3, half-maximal inhibitory concentration: 84.4 nM
Estimate against measurement, compound 3: 2.1-fold (0.32 log units) below; the measured number falls inside the stated range.
By their numbers in this assay, from the lowest: compound 2; then compounds 3 and 1 (each within the scatter of the next).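

In this assay, for the compounds shown here, the exchange of 3-methylphenyl for 4-chlorophenyl on the sulfonamide nitrogen gives a 2.0-fold higher number from compound 2 to compound 3 (0.31 log units; beyond the scatter) and is the first measured step, so the aryl group at this place is not interchangeable, though the effect of this change is modest. The two groups match in heavy-atom count, in the single six-membered aromatic ring of carbon only, and in hydrogen-bond donors, acceptors and net charge, so none of these counted features separates them; they differ in the substituent and in where it stands on the ring, and this single step cannot divide the shift between those two differences. No measured property in hand bears on the origin of this step.

Still open, from the compounds shown here alone, is whether the step follows the chlorine or its placement, which 3-chlorophenyl or 4-methylphenyl on the same nitrogen would help to settle, and how a carboxylic acid or an amine on that ring would read. The effect of chain length cannot be read from these compounds, since compound 1 differs from the others in more than one place.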